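Benzyl on the ring nitrogen of compound 1

The source may report more compounds than this note shows. Statements on the series, on what has been measured and on what is new or still open speak of the compounds shown alone.

Measured so far in a functional assay on Bel7402/5-FU cells (Homo sapiens) for antiproliferative activity, read by MTT assay, with a stated time of 72 h (a higher number here means a weaker inhibitor, a lower number a stronger inhibitor), both values being limits of the assay
- compound 1 `C=C1C(=O)O[C@H]2[C@H]1CC/C(COC(=O)Cn1cc(F)c(=O)[nH]c1=O)=C\CC[C@@]1(C)O[C@@H]21` gives > 20000 nM
- compound 2 `C=C1C(=O)O[C@H]2[C@H]1CC/C(COC(=O)CCC(=O)NCCCCCCNC(=O)Cn1cc(F)c(=O)[nH]c1=O)=C\CC[C@@]1(C)O[C@@H]21` gives > 20000 nM

Compound 1 stands at a limit and not at a number (> 20000 nM). Compound 2 likewise gives only a limit (> 20000 nM). Within the data shown here, neither value can be ranked against the other, and the series offers no measured step to scale from.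

The next compound is compound 3 `C=C1C(=O)O[C@H]2[C@H]1CC/C(COC(=O)Cn1cc(F)c(=O)n(Cc3ccccc3)c1=O)=C\CC[C@@]1(C)O[C@@H]21`, which differs from compound 1 by one change (benzyl in place of hydrogen on an aromatic nitrogen), namely benzyl in place of hydrogen on an aromatic nitrogen. Among the measured compounds shown here, with no measured step to draw on, the expectation rests only on the floor of activity set by compound 1 (> 20000 nM). Only a small shift is expected in this assay, if one can be seen at all, towards a stronger inhibitor, and the estimated step is an at least 1.3-fold lower number from compound 1 to compound 3 (0.12 log units; that floor lies within the scatter) ( a further limit is as likely as a number ). For compound 3 the expected value is 15000 nM, with an estimated range from 6000 nM to 40000 nM ( four of five repeats ).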

Compound 3, half-maximal inhibitory concentration: 4270 nM
Beside the measured number, compound 3's estimate is 3.5-fold (0.55 log units) above it; the measured number lies below the stated range.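

In this assay, the aromatic nitrogen that carries hydrogen in compound 1 accepts a substituent: benzyl at this position gives the series its first measured number instead of a limit. The step is an at least 4.6-fold lower number from compound 1 to compound 3 (0.67 log units; beyond the scatter), so this single change, which adds one six-membered aromatic ring of carbon only and removes the hydrogen on that nitrogen, is enough to bring the compound within the measurable range of the assay. The full size of the step remains unknown, and the measured number in compound 3 stands against a starting point that is a limit and not a number: the limit of > 20000 nM in this assay, at which 2 of the 3 values shown sit.

Open, as far as these compounds go, is whether the aromatic ring of the benzyl matters or whether a simpler group on the same nitrogen, such as methyl or a longer alkyl chain, would serve equally, and the same question applies to a benzyl ring carrying an amine or a carboxylic acid. Also open, from the compounds shown here alone, is whether benzyl on this nitrogen would have a similar effect in the longer hexyl-containing chain of compound 2.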